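Benzyloxy in Place of Chloro on the Benzyl Group

A few compounds are considered here, and "the series" means these few. Any claim that something is new, unique, unknown or untested is made for them only; others in the source may bear on it.

Of the compounds shown here, three with a shared core have been measured. Compound 1 `COc1ccc(Cn2c(=O)n(C3OC(CO)[C@@H](O)[C@H]3O)c3nc(N)nc(O)c32)cc1` gives 44% in a functional assay on the whole organism (B cells) with Mus musculus as the target; a lower number here means a smaller maximal response, a higher number a larger maximal response. Compound 2 `Nc1nc(O)c2c(n1)n(C1OC(CO)[C@@H](O)[C@H]1O)c(=O)n2Cc1ccc(Cl)cc1` gives 15%, the second highest of the three, while compound 3 `CCCCCCCCCCn1c(=O)n(C2OC(CO)[C@@H](O)[C@H]2O)c2nc(N)nc(O)c21` gives 0%. The steps are a number 29 percentage points lower from compound 1 to compound 2 (beyond the scatter), a number 44 percentage points lower from compound 1 to compound 3 (beyond the scatter) and a number 15 percentage points lower from compound 2 to compound 3 (beyond the scatter).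

Compound 4 `Nc1nc(O)c2c(n1)n(C1OC(CO)[C@@H](O)[C@H]1O)c(=O)n2Cc1ccc(OCc2ccccc2)cc1` differs from compound 2 by benzyloxy in place of chloro on an aromatic carbon. The step from compound 1 to compound 2 bears most on this change, since benzyloxy, like methoxy, is joined through an oxygen and the chloro leaves again. He therefore expects a modest rise, a number 20 percentage points higher from compound 2 to compound 4 (beyond the scatter), though the larger benzyloxy leaves the size uncertain. For compound 4 he estimates 35%, within a range of 10% to 60%.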

Compound 4, largest response reached (reported as maximal response), in percent of the reference or control that the assay uses: 5%
Compound 4: middle estimate off by 30 percentage points, on the high side; the whole stated range lies above it.
By their numbers in this assay, from the lowest: compounds 3, 4 and 2 (each within the scatter of the next, the first and the last beyond it); then compound 1.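

In this assay benzyloxy in place of chloro gives a number 10 percentage points lower from compound 2 to compound 4 (within the scatter) and so an oxygen link on the aromatic carbon does not by itself bring a response near that of compound 1. Phenyl in place of hydrogen on the saturated chain carbon bound to that oxygen gives a number 39 percentage points lower from compound 1 to compound 4 (beyond the scatter) and so this one added ring is enough to lose most of the response. No evidence is available to explain this. Going by these compounds, whether ethoxy, an amine or a carboxylic acid at this place would stand nearer compound 1 or compound 4 remains open.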